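Swapping a hydroxymethyl amide side chain for a diacid

This account rests on a few compounds, and the source may have more. Where it says the series, first, only, none or still open, it means among the compounds named here.

Compound 2 `CCn1c(C(=O)N[C@H](C)CO)ccc1C(CC)(CC)c1ccc(OCS(=O)(=O)c2ccccc2)c(C)c1` gives 10600 nM in a functional assay on MCF7 cells (Homo sapiens) for antiproliferative activity, read by MTT assay, with a stated time of 24 h (on this read-out higher numbers stand for weaker inhibition and lower numbers for stronger inhibition), the lowest of the two numbers obtained so far. Compound 3 `CCn1c(C(=O)NC2(CO)CC2)ccc1C(CC)(CC)c1ccc(OCS(=O)(=O)c2ccccc2)c(C)c1` gives 28800 nM, so that a 2.7-fold higher number from compound 2 to compound 3 (0.43 log units; beyond the scatter). Compound 1 `CCn1c(C(=O)N[C@@H](CC(=O)OC)C(=O)OC)ccc1C(CC)(CC)c1ccc(OCS(=O)(=O)c2ccccc2)c(C)c1` reaches only the limit of this assay, > 50000 nM. The new compound 4 `CCn1c(C(=O)N[C@H](CC(=O)O)C(=O)O)ccc1C(CC)(CC)c1ccc(OCS(=O)(=O)c2ccccc2)c(C)c1` differs from compound 2 by 1,2-dicarboxyethyl in place of 1-(hydroxymethyl)ethyl on an amide-type nitrogen. Within the data shown here, the steps that bear on this change are an at least 4.7-fold lower number from compound 1 to compound 2 (0.67 log units; beyond the scatter) and an at least 1.7-fold lower number from compound 1 to compound 3 (0.23 log units; that floor lies within the scatter), where the 1,2-bis(methoxycarbonyl)ethyl group of compound 1 is the nearest relative of the 1,2-dicarboxyethyl group entering compound 4 and sits at the limit of > 50000 nM in this assay, at which 1 of the 3 values shown sits. A higher number is therefore expected for compound 4, a step of a 3.8-fold higher number from compound 2 to compound 4 (0.58 log units; beyond the scatter), at least modest in size. Compound 4 is estimated at 40000 nM, within 15000 nM to 100000 nM.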

Compound 4, half-maximal inhibitory concentration: > 50000 nM
Compound 4 gave a limit, no number; the forecaster's own chance of this, stated with the estimate: 50%; middle value at least 1.2-fold (0.09 log units) away from the limit.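

In this assay, 1,2-dicarboxyethyl in place of 1-(hydroxymethyl)ethyl on the amide-type nitrogen gives an at least 4.7-fold higher number from compound 2 to compound 4 (0.67 log units; beyond the scatter), so freeing both esters of the side chain does not bring back the lower number. Against 1-(hydroxymethyl)cyclopropyl the result is an at least 1.7-fold higher number from compound 3 to compound 4 (0.23 log units; that floor lies within the scatter), and that floor settles no order. Compound 1 and compound 4 both give limits rather than numbers, so the step between them cannot be read: the limit of > 50000 nM in this assay, at which 2 of the 4 values shown sit.

Still open, from the compounds shown here alone, is whether a side chain carrying a single carboxylic acid, or an amine, would stay at that limit or come closer to compound 2.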